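Para substituent swap on the benzoyl ring of the series

The source may report more compounds than this note shows. Statements on the series, on what has been measured and on what is new or still open speak of the compounds shown alone.

For the measured compounds named here, compound 1 `CC(/C=N/Nc1ccc([N+](=O)[O-])cc1)=N\NC(=O)c1ccccc1N` is the one member with a number: in a functional assay on cells (Splenocyte, Mus musculus, strain BALB/c) for inhibition, read by scintillation counting and thymidine incorporation, with a stated time of 72 h (a lower number here means a stronger inhibitor, a higher number a weaker inhibitor), compound 1 gives 4900 nM. Compound 2 `CC(/C=N/Nc1ccc([N+](=O)[O-])cc1)=N\NC(=O)c1ccc(C(F)(F)F)cc1` returns only a limit of the assay; in this assay compound 2 gives > 12000 nM. Compound 3 `COc1ccc(C(=O)N/N=C(C)/C=N/Nc2ccc([N+](=O)[O-])cc2)cc1` likewise returns a limit, giving > 12000 nM in this assay. Compound 3 thus stands at the limit of > 12000 nM in this assay, at which 2 of the 3 values shown sit, with no number of its own. The step of an at least 2.4-fold higher number from compound 1 to compound 3 (0.38 log units; beyond the scatter) is readable only as a bound; the step that the two limits leave unreadable from compound 2 to compound 3 is not readable.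

Compound 4 `CC(/C=N/Nc1ccc([N+](=O)[O-])cc1)=N\NC(=O)c1ccc(Cl)cc1` differs from compound 3 by chloro in place of methoxy on an aromatic carbon. Both measured steps bear on it, and neither gives a size: one is a bound away from compound 1, the other has both ends at the limit. Compound 2 carries trifluoromethyl at the same place and its value is a limit, > 12000 nM. Compound 3 with methoxy is a limit as well. With chloro at that place compound 4 is expected to stay where both of them stand, and the expected step is a step that the limit leaves unreadable from compound 3 to compound 4, none beyond the scatter. Compound 4 is expected at 15000 nM, between 6000 nM and 40000 nM, most likely reported again as a limit.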

Compound 4, half-maximal inhibitory concentration: 4200 nM
For compound 4 the middle estimate is 3.6-fold (0.55 log units) above the measured one; measured number outside the range, below it.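

This position does not behave uniformly in this assay: chloro gives a measured number where methoxy and trifluoromethyl give only limits of the assay, with an at least 2.8-fold lower number from compound 3 to compound 4 (0.45 log units; beyond the scatter) and an at least 2.8-fold lower number from compound 2 to compound 4 (0.45 log units; beyond the scatter) on the change to chloro. A 2-aminophenyl on the carbonyl carbon is also not the only route to a measured number, as a 1.2-fold lower number from compound 1 to compound 4 (0.07 log units; within the scatter) places 4-chlorophenyl level with it. Both steps to chloro remain bounds, and the limit is shared by the methoxy and trifluoromethyl compounds: the limit of > 12000 nM in this assay, at which 2 of the 4 values shown sit.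

The true distance of methoxy and trifluoromethyl from chloro cannot be read, nor can the step between those two groups. On these data alone, whether bromo, methyl or an amine at this carbon would track chloro or sit at the limit remains open.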